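Swapping the chain on compound 2 for a hydroxy group

The source may hold more compounds than are shown below. What is called first, only, known or untested is meant among the compounds shown, and "the series" means these compounds.

Within the data shown here, compound 2, `[C-]#[N+]Cc1c(C)nc2c(OCc3ccccc3)cccn12`, stands highest of the two compounds measured so far in a functional assay on the whole organism with Rattus norvegicus as the target, with a stated time of 4 h, at a dose of 40 mg/kg by the intraperitoneal route (a higher number here means more inhibition at the dose given (going by the name of the read-out), a lower number less inhibition), where compound 2 gives 96%. Its nearest neighbour is compound 1, `CC(=O)c1c(C)nc2c(OCc3ccccc3)cccn12`, which in this assay gives 57%. Among the measured compounds shown here, the one measured step, a number 39 percentage points higher from compound 1 to compound 2 (beyond the scatter), changes the group on the same aromatic carbon that carries the chain of interest here.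

Compound 3, `Cc1nc2c(OCc3ccccc3)cccn2c1CO`, differs from compound 2 by one oxygen atom in place of a group of 2 heavy atoms (1 carbon, 1 nitrogen; no ring), on a saturated chain carbon bound to an aromatic carbon. The step from compound 1 to compound 2 bears on this only loosely: it shows that exchanging a small group at this spot can move the inhibition by a large amount, so a change beyond the scatter is plausible, and because compound 2 already gives 96% the room upward is small. A downward step, a number 26 percentage points lower from compound 2 to compound 3 (beyond the scatter), is therefore expected, and compound 3 is estimated at 70%, within a range from 40% to 95%.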

Compound 3, a percentage reported as inhibition, in the whole organism at one dose (the size of the read-out at that dose, not a potency): 99%
Compound 3: middle estimate off by 29 percentage points, on the low side; measured number above the stated range.
By their numbers in this assay, from the lowest: compound 1; then compounds 2 and 3 (each within the scatter of the next).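

In this assay, the step at the saturated chain carbon is a number 3 percentage points higher from compound 2 to compound 3 (within the scatter) when a hydroxy group replaces the chain of compound 2. This position therefore accepts two quite different ends, one with a triple bond and no hydrogen-bond donor and one with a hydrogen-bond donor, and at this dose the read-out does not separate them. Hydroxymethyl in place of acetyl on the aromatic carbon gives a number 42 percentage points higher from compound 1 to compound 3 (beyond the scatter), so among these compounds acetyl is the group that stands apart, though nothing shown here offers a reason for this.

From the compounds shown here alone, whether an amine, a carboxylic acid or a longer chain on this carbon would keep the inhibition remains open. The read-out gives the size of the effect at a single dose rather than a potency, so compound 2 and compound 3 might still differ at lower doses.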